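The source may report more compounds than this note shows. Statements on the series, on what has been measured and on what is new or still open speak of the compounds shown alone.

Of the compounds shown here, three have been tested in an ADME assay on Huh-7 cells (Homo sapiens) for cytotoxicity; on this read-out higher numbers stand for lower toxicity in this test and lower numbers for higher toxicity in this test. Compound 2 `CCCN1CCC(CNCc2cn(-c3ccc([N+](=O)[O-])cc3)nc2-c2ccc(OC(F)(F)F)cc2)CC1` gives 18000 nM. Compound 1 `CN1CCN(CCCNCc2cn(-c3ccc([N+](=O)[O-])cc3)nc2-c2ccc(OC(F)(F)F)cc2)CC1` gives 1600 nM. Compound 3 `CCCN1CCC(CNCc2cn(-c3ccc([N+](=O)[O-])cc3)nc2-c2ccc(C(F)(F)F)cc2)CC1` gives 2300 nM. Compound 1 differs from compound 2 by 2-(4-methylpiperazin-1-yl)ethyl in place of 1-propylpiperidin-4-yl on a saturated chain carbon bound to an amine nitrogen, a change that came with an 11-fold lower number from compound 2 to compound 1 (1.05 log units; beyond the scatter). Compound 3 differs from compound 2 in its core by trifluoromethyl in place of trifluoromethoxy on an aromatic carbon, which came with a 7.8-fold lower number from compound 2 to compound 3 (0.89 log units; beyond the scatter). Compound 4 `CN1CCN(CCCNCc2cn(-c3ccc([N+](=O)[O-])cc3)nc2-c2ccc(C(F)(F)F)cc2)CC1` carries the core of compound 3 together with 2-(4-methylpiperazin-1-yl)ethyl in place of 1-propylpiperidin-4-yl on a saturated chain carbon bound to an amine nitrogen, the same change at the same place as that from compound 2 to compound 1. If that change acts alike on the core of compound 3, a step close to the earlier one is expected, roughly a 5.8-fold lower number from compound 3 to compound 4 (0.76 log units; beyond the scatter). Compound 4 is therefore expected to give about 400 nM. Among the compounds with values here, only one earlier pair shows this change, so the expected range for compound 4 is set wide, estimated from 150 nM to 1500 nM.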

Compound 4, half-maximal cytotoxic concentration: 4900 nM
Compound 4: middle estimate off by 12-fold (1.09 log units), on the low side, outside the stated range (above it).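

In this assay, the change to 2-(4-methylpiperazin-1-yl)ethyl did not carry over from one core to the other; on the core of compound 3 it gave a 2.1-fold higher number from compound 3 to compound 4 (0.33 log units; beyond the scatter), a step opposite in direction to the earlier one: the same change on two cores in this assay, an 11-fold lower number (1.05 log units; beyond the scatter) from compound 2 to compound 1 and a 2.1-fold higher number (0.33 log units; beyond the scatter) from compound 3 to compound 4, 24-fold (1.38 log units) apart, beyond the scatter of two such steps. The change to trifluoromethyl also reversed direction, giving a 3.1-fold higher number from compound 1 to compound 4 (0.49 log units; beyond the scatter): the same change on two cores in this assay, a 7.8-fold lower number (0.89 log units; beyond the scatter) from compound 2 to compound 3 and a 3.1-fold higher number (0.49 log units; beyond the scatter) from compound 1 to compound 4, 24-fold (1.38 log units) apart, beyond the scatter of two such steps. Within these four compounds, the effect of each change therefore depends on the group present at the other place, but the data do not show why, or whether this holds on any other core.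

As far as these compounds go, it remains open how the two side chains would behave with a chlorine atom or a methoxy group on that aromatic carbon. A longer chain on the amine nitrogen is also untested among the compounds shown.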